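From pyrimidin-2-yl to pyridazin-3-yl in compound 1

A few compounds are considered here, and "the series" means these few. Any claim that something is new, unique, unknown or untested is made for them only; others in the source may bear on it.

Of the compounds shown here, two built on a shared core have so far been measured in a functional assay on HT-29 cells (Homo sapiens) for antiproliferative activity, read by sulforhodamine B assay; on this read-out higher numbers stand for weaker inhibition and lower numbers for stronger inhibition. Compound 1 `C/C(=N\Nc1nc2ccccc2o1)c1ncccn1` gives 270 nM, and compound 2 `C/C(=N\Nc1nc2ccccc2o1)c1cc2ccccc2cn1` gives 40 nM. Compound 1 therefore holds the higher number of the two, which means the weaker inhibition, and its gap to compound 2 lies beyond the usual scatter of repeated measurements.

Compound 3 `C/C(=N\Nc1nc2ccccc2o1)c1cccnn1` has not yet been measured. It carries pyridazin-3-yl in place of pyrimidin-2-yl on a carbon with a double bond to nitrogen. The two compounds have the same atoms, joined differently, and both groups are a six-membered aromatic ring with 2 hetero atoms. Among the compounds with values here, no measured pair shows what a change of this kind does, so the best starting point is compound 1 at 270 nM. The expected change is a 1.4-fold lower number from compound 1 to compound 3 (0.13 log units; within the scatter), which would be no step beyond the scatter. For compound 3 the estimated value is 200 nM, with an expected range from 60 nM to 650 nM.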

Compound 3, half-maximal inhibitory concentration: 2640 nM
Compound 3: middle estimate off by 13-fold (1.12 log units), on the low side, outside the stated range (above it).
By their numbers in this assay, from the lowest: compound 2; then compound 1; then compound 3.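

In this assay, moving from pyrimidin-2-yl to pyridazin-3-yl on a carbon with a double bond to nitrogen gives a 9.8-fold higher number from compound 1 to compound 3 (0.99 log units; beyond the scatter). Within the data shown here, the earlier compounds could not show this, since this pair is the first to show that the place is sensitive to how the atoms of the ring are joined, even when the atoms themselves stay the same: both groups are a six-membered aromatic ring with 2 hetero atoms, with matching counts of heavy atoms, hydrogen-bond donors and hydrogen-bond acceptors, so those counts alone do not tell these two groups apart here. No measurement at hand explains why the rearranged ring gives the weaker inhibition.

The compounds shown leave open how other rings would behave at this place, such as pyrazin-2-yl, with the same atoms joined in yet another way, or pyridin-2-yl and phenyl, with fewer ring nitrogens. They also leave open whether the same exchange would give a step of similar size on a core other than that of compound 1.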